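The source may report more compounds than this note shows. Statements on the series, on what has been measured and on what is new or still open speak of the compounds shown alone.

Series notes, amide-aryl exchange.

Within the data shown here, compound 2 `C=CC(=O)Nc1cccc(NC(=O)CSc2nc(Nc3ccccc3)c3ccccc3n2)c1` is the lower of the two numbers so far in a functional assay on MGC-803 cells (Homo sapiens) for inhibition, read by MTT assay, with a stated time of 72 h; a higher number here means a weaker inhibitor, a lower number a stronger inhibitor: compound 2 gives 7310 nM, while compound 1 `COc1cccc(NC(=O)CSc2nc(Nc3ccccc3)c3ccccc3n2)c1` gives 10000 nM. Among the measured compounds shown here, the only measured step, a 1.4-fold lower number from compound 1 to compound 2 (0.14 log units; within the scatter), puts (vinylcarbonyl)amino in place of methoxy on an aromatic carbon and stays within the scatter, so the two compounds are not distinguished on this assay.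

Compound 3 `O=C(CSc1nc(Nc2ccccc2)c2ccccc2n1)Nc1ccc(Cl)cc1` changes the amide aryl group itself: 4-chlorophenyl in place of 3-((vinylcarbonyl)amino)phenyl on an amide-type nitrogen. For the measured compounds named here, no measured step touches this position in the same way; the one step in hand, a 1.4-fold lower number from compound 1 to compound 2 (0.14 log units; within the scatter), alters only a substituent on the aryl ring and shows that such a change left the number essentially where it was. Going by the values given here, with that as the sole guide, no movement beyond the scatter is expected in this assay from compound 2 to compound 3, and the expected step is a 1.2-fold higher number from compound 2 to compound 3 (0.09 log units; within the scatter).

Compound 3 is therefore estimated at 9000 nM in this assay, with an expected range from 3000 nM to 27000 nM.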

Compound 3, half-maximal inhibitory concentration: 40400 nM
Compound 3: the middle estimate sits 4.5-fold (0.65 log units) below what was measured; measured number outside the range, above it.
By their numbers in this assay, from the lowest: compounds 2 and 1 (each within the scatter of the next); then compound 3.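

The aryl group on the amide-type nitrogen is a place where the number in this assay can move beyond the scatter: there is a 5.5-fold higher number from compound 2 to compound 3 (0.74 log units; beyond the scatter), and, with 4-chlorophenyl in place of 3-methoxyphenyl, a 4.0-fold higher number from compound 1 to compound 3 (0.61 log units; beyond the scatter). Since compound 1 and compound 2 lie within the scatter of each other, both steps lead the same way, and compound 3 is the weakest inhibitor of the three, with its steps to both others printed as beyond the scatter. No measurement is available that bears on the reason for this rise.

Whether the chlorine itself accounts for the higher number stays open, and a plain phenyl or a pyridyl ring on the same amide-type nitrogen would speak to that. Also open, on these data alone, is whether any group at this place brings the number clearly below that of compound 2, for instance a carboxylic acid or a dimethylaminomethyl group on the aryl ring.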